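Swapping the aryl group on the sulfonamide of compound 2

This account rests on a few compounds, and the source may have more. Where it says the series, first, only, none or still open, it means among the compounds named here.

Measured compounds:
compound 1 `Cc1cc(C)cc(C(=O)Nc2cccc(/C=C/C(=O)c3nc4ccccc4[nH]3)c2)c1`: 4020 nM
compound 2 `O=C(/C=C/c1cccc(NS(=O)(=O)c2cccc(Cl)c2)c1)c1nc2ccccc2[nH]1`: 2510 nM

Among the measured compounds shown here, in a functional assay on 143B cells (Homo sapiens) for antiproliferative activity, read by MTT assay, with a stated time of 48 h (a higher number here means a weaker inhibitor, a lower number a stronger inhibitor), compound 2 gives 2510 nM, the smaller of the two numbers, yet the only measured step, a 1.6-fold lower number from compound 1 to compound 2 (0.20 log units; within the scatter), is within the scatter, so the two compounds are not distinguished. Compound 3 `Cc1ccc(S(=O)(=O)Nc2cccc(/C=C/C(=O)c3nc4ccccc4[nH]3)c2)cc1` differs from compound 2 by 4-methylphenyl in place of 3-chlorophenyl on a sulfonyl sulfur. For the measured compounds named here, no measured step exchanges one aryl group for another on a sulfonyl sulfur; the one measured step changed the whole group on the nitrogen and stayed within the scatter. The expected step of a 1.1-fold higher number from compound 2 to compound 3 (0.05 log units; within the scatter) is therefore nothing beyond the scatter. Compound 3 is expected at about 2800 nM, in a range of 1000 nM to 8000 nM.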

Compound 3, half-maximal inhibitory concentration: 3220 nM
Compound 3: middle estimate off by 1.2-fold (0.06 log units), on the low side; the range from low to high includes it.
By their numbers in this assay, from the lowest: compounds 2, 3 and 1 (each within the scatter of the next).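

Among the compounds shown here, this is the first exchange of one aryl group for another on a sulfonyl sulfur: in this assay, 4-methylphenyl in place of 3-chlorophenyl gives a 1.3-fold higher number from compound 2 to compound 3 (0.11 log units; within the scatter) and so does not separate the two groups. With (4-methylphenyl)sulfonyl in place of (3,5-dimethylphenyl)carbonyl on the nitrogen, the result is a 1.2-fold lower number from compound 1 to compound 3 (0.10 log units; within the scatter) and a second sulfonyl compound also stays unseparated from the carbonyl compound. Nothing available explains how close these numbers lie. Still open, on these data alone, is whether an amine or a carboxylic acid on this aryl ring, or a longer chain in its place, would give a step beyond the scatter.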